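The source may report more compounds than this note shows. Statements on the series, on what has been measured and on what is new or still open speak of the compounds shown alone.

Of the compounds shown here, two of a shared core have been measured in a functional assay on the whole organism (artery, strain albino) with Rattus norvegicus as the target, with a stated time of 600 min, at a dose of 10 mg/kg by the oral route; on this read-out lower numbers stand for less inhibition and higher numbers for more inhibition at the one dose given (going by the name of the read-out). Compound 1, `CC1=C(C(=O)Nc2ccc(F)cc2)C(c2ccc([N+](=O)[O-])cc2)N=C(SCc2ccc(Cl)cc2)N1`, gives 28.2% in this assay. Compound 2, `CC1=C(C(=O)Nc2ccc(Br)cc2)C(c2ccc(Cl)cc2Cl)N=C(SCc2ccccc2Cl)N1`, gives 24.6% in this assay, the lowest of the two numbers on record; compound 1 stands a little higher, but the gap between the two is within the scatter, so no order can be read from it. Going by the values given here, compound 1 also carries a 4-chlorobenzyl on the sulfur, yet it differs from compound 2 in further places, and so no single step joins the two.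

The next compound, compound 3, `CC1=C(C(=O)Nc2ccc(Br)cc2)C(c2ccc(Cl)cc2Cl)N=C(SCc2ccc(Cl)cc2)N1`, differs from compound 2 in one place only: 4-chlorophenyl in place of 2-chlorophenyl on a saturated chain carbon bound to a sulfur. Among the compounds with values here, since no step between measured compounds is known, there is nothing in these numbers that would point to a change in either direction. Compound 3 is therefore expected to lie close to compound 2, the estimated step being a number 1.4 percentage points higher from compound 2 to compound 3 (within the scatter), that is none beyond the scatter. In this assay compound 3 is estimated at 26%, with a likely range from 12% to 40%.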

Compound 3, a percentage reported as inhibition, in the whole organism at one dose (the size of the read-out at that dose, not a potency): 30.3%
For compound 3 the middle estimate is 4.3 percentage points below the measured one; the range from low to high includes it.
By their numbers in this assay, from the lowest: compounds 2, 1 and 3 (each within the scatter of the next).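

Going by these compounds alone, the first step that can be read at this position, from (2-chlorobenzyl)sulfanyl to (4-chlorobenzyl)sulfanyl, comes in this assay as a number 5.7 percentage points higher from compound 2 to compound 3 (within the scatter) and so does not separate the two compounds. With the same atoms joined differently and all else in the molecule held the same, this read-out at the one dose given cannot tell the 2-chlorophenyl from the 4-chlorophenyl on this chain carbon, and the position of the chlorine on that ring is not shown to matter in this pair. Within the data shown here, nothing on record bears on what lies behind this result, and the single pair cannot show whether a larger difference is hidden within the scatter.

The compounds shown leave open whether anything other than a chlorobenzyl on the sulfur would move the number beyond the scatter, for example a plain benzyl, a longer alkyl chain or a benzyl carrying an amine or a carboxylic acid. They also leave open whether the same exchange would read alike with the rest of compound 1 in place, as that compound differs from compound 3 in further places.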